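A few compounds are considered here, and "the series" means these few. Any claim that something is new, unique, unknown or untested is made for them only; others in the source may bear on it.

Measured compounds:

compound 1 `Cc1c(C#Cc2ccc(CCC(=O)O)cc2)ccnc1Cl` gives 101%
compound 2 `O=C(O)CCc1ccc(C#Cc2ccnc(Cl)c2)cc1` gives 94%
compound 3 `O=C(O)CCc1ccc(C#Cc2ccnc(Cl)c2Cc2ccccc2)cc1` gives 101%

In an in vitro functional assay on 1321-N1 cells for agonist activity at Free fatty acid receptor 1 (Homo sapiens), read by fluorescence, spectrophotometry and calcium flux (on this read-out lower numbers stand for smaller maximal responses and higher numbers for larger maximal responses), compound 3 reaches 101%. Compound 3 stands level with compound 1, the two together at the top of the three numbers, and its nearest neighbour is compound 1 with no change at the digits printed from compound 1 to compound 3 (within the scatter). Its furthest neighbour is compound 2, with a number 7 percentage points higher from compound 2 to compound 3 (within the scatter), still within the scatter.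

Compound 4 `C=CCc1c(C#Cc2ccc(CCC(=O)O)cc2)ccnc1Cl` differs from compound 3 in one place: vinyl in place of phenyl on a saturated chain carbon bound to an aromatic carbon. The change sits on the saturated chain carbon bound to an aromatic carbon, the same place that was varied before. Within the data shown here, the steps that bear on it are all small: no change at the digits printed from compound 1 to compound 3 (within the scatter), a number 7 percentage points higher from compound 2 to compound 3 (within the scatter) and a number 7 percentage points lower from compound 1 to compound 2 (within the scatter), each within the scatter. Three changes at this position left the maximal response essentially unchanged, so no step beyond the scatter is expected here either; the expected step is a number 2 percentage points lower from compound 3 to compound 4 (within the scatter). Compound 4 is therefore estimated at 99%, with a range from 86% to 110%.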

Compound 4, largest response reached (reported as efficacy), in percent of the reference or control that the assay uses: 97%
Compound 4: the middle estimate sits 2 percentage points above what was measured, within the range that was stated.
By their numbers in this assay, from the lowest: compounds 2, 4, 1 and 3 (each within the scatter of the next).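

In this assay, the step to a group with no ring and a double bond outside aromatic rings stays small, a number 4 percentage points lower from compound 3 to compound 4 (within the scatter), so at this place on the saturated chain carbon bound to an aromatic carbon, the phenyl of the benzyl group can give way to vinyl without a step beyond the scatter. The allyl group likewise leaves the response within the scatter of the two smaller substituents, with a number 3 percentage points higher from compound 2 to compound 4 (within the scatter) for allyl in place of hydrogen and a number 4 percentage points lower from compound 1 to compound 4 (within the scatter) for vinyl in place of hydrogen on the methyl carbon. The data shown give no reason for this flat response.

Going by these compounds, whether an amine or a longer chain at this place would also stay within the scatter remains open. So does whether any group here can move the maximal response at all.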